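The compounds below may be only part of what the source reports. "The series", "measured", "known", "first", "only" and "open" are said of these compounds alone.

Measured compounds:
compound 1, `N=C(N)NCCC[C@H](NC(=O)CN(c1nc(Cl)nc2[nH]cnc12)C1CC1)C(=O)OCc1ccccc1`, 30.4%
compound 2, `NC(=O)C[C@H](NC(=O)CN(c1nc(Cl)nc2[nH]cnc12)C1CC1)C(=O)O`, 20.1%
compound 3, `NC(=O)CC[C@H](NC(=O)CN(c1nc(Cl)nc2[nH]cnc12)C1CC1)C(=O)OCc1ccccc1`, 42.8%

In a functional assay on the whole organism (Tail, strain ICR) with Mus musculus as the target, in the tail flick test, with a stated time of 90 min, at a dose of 25 umol/kg by the oral route (on this read-out higher numbers stand for a stronger effect at the one dose given and lower numbers for a weaker effect), compound 3 stands highest of the three numbers. Its nearest neighbour is compound 1, and the step of a number 12.4 percentage points higher from compound 1 to compound 3 (beyond the scatter) lies beyond the scatter; compound 2 lies furthest below it.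

Compound 4, `NC(=O)C[C@H](NC(=O)CN(c1nc(Cl)nc2[nH]cnc12)C1CC1)C(=O)OCc1ccccc1`, has not yet been measured. It differs from compound 3 in one place: carbamoyl in place of carbamoylmethyl on a saturated chain carbon, two bonds along the chain from an amide-type nitrogen and a carbonyl carbon. Put another way, the change reads 2-carbamoylethyl to carbamoylmethyl.

Among the compounds with values here, none of the measured steps follows exactly this change. Within the data shown here, the only single-place step, a number 12.4 percentage points higher from compound 1 to compound 3 (beyond the scatter), swaps a different side group altogether and was modest in size. Compound 2 carries the same carbamoylmethyl group as compound 4 but differs from compound 3 in a second place as well, so its value in this assay can only be set beside that of compound 3 without a computed step. Compound 2 gives 20.1%, while compound 3 gives 42.8%.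

On this thin ground a small downward shift is expected, a number 9.8 percentage points lower from compound 3 to compound 4 (within the scatter), though one that may not clear the scatter. Compound 4 is therefore estimated at 33%, within a range from 16% to 50%.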

Compound 4, a percentage reported as activity, at one dose (the size of the read-out at that dose, not a potency): 32.3%
The estimate for compound 4 lay 0.7 percentage points above the measured number, within the range that was stated.
By their numbers in this assay, from the lowest: compound 2; then compounds 1 and 4 (each within the scatter of the next); then compound 3.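

In this assay, within the data shown here, shortening the side group from 2-carbamoylethyl to carbamoylmethyl on this saturated chain carbon lowers the number (a number 10.5 percentage points lower from compound 3 to compound 4 (beyond the scatter)), which is the first measured pair to differ only in the length of this carbamoyl-bearing chain, and so the first direct sign that this length matters for compounds. Compound 4 also gives the first single-place reading at the oxygen next to a carbonyl group, where benzyl in place of hydrogen is accompanied by a higher number (a number 12.2 percentage points higher from compound 2 to compound 4 (beyond the scatter)), so the carbamoylmethyl compounds shown respond to that change as well. The side group of compound 4 and the larger one of compound 1, which holds 3 nitrogen atoms, cannot be told apart in this read-out (a number 1.9 percentage points higher from compound 1 to compound 4 (within the scatter)), so a change of side group at this carbon does not always move the number.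

As far as these compounds go, whether an amine or a carboxylic acid at the end of this side chain, or a chain longer than 2-carbamoylethyl, would raise or lower the number remains open. Nothing available here explains why these numbers shift.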